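The compounds below may be only part of what the source reports. "The series", "measured", "known", "first", "only" and "open" are said of these compounds alone.

Going by the values given here, compound 2 `COc1cc2c(Oc3ccc(NC(=O)c4cn(-c5cc(C)ccc5C)cn4)cc3F)ccnc2cc1OCCCN1CCCCC1` has the higher of the two numbers so far in a functional assay on HT-29 cells (Homo sapiens) for cytotoxicity, read by MTT assay, with a stated time of 72 h (on this read-out higher numbers stand for weaker inhibition and lower numbers for stronger inhibition), where compound 2 gives 580 nM. Among the compounds with values here, compound 1 `COc1cc2c(Oc3ccc(NC(=O)c4cn(-c5ccccc5OC)cn4)cc3F)ccnc2cc1OCCCN1CCCCC1` gives 100 nM, and the only measured step, a 5.8-fold higher number from compound 1 to compound 2 (0.76 log units; beyond the scatter), shows that swapping the group on the aromatic nitrogen matters. Compound 3 `COc1cc2c(Oc3ccc(NC(=O)c4cn(-c5ccc(Cl)cc5Cl)cn4)cc3F)ccnc2cc1OCCCN1CCCCC1` carries 2,4-dichlorophenyl in place of 2,5-dimethylphenyl on an aromatic nitrogen. Within the data shown here, since this again changes only that ring, and no measured step tests a dichlorophenyl, compound 3 is expected to stay near compound 2, with a 1.5-fold lower number from compound 2 to compound 3 (0.16 log units; within the scatter) lying within the scatter. The estimate for compound 3 is 400 nM, between 130 nM and 1300 nM.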

Compound 3, half-maximal inhibitory concentration: 4300 nM
Compound 3: the middle estimate sits 11-fold (1.03 log units) below what was measured; measured number outside the range, above it.
By their numbers in this assay, from the lowest: compound 1; then compound 2; then compound 3.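

In this assay, the ring on the aromatic nitrogen proves more sensitive than the first step showed: swapping 2,5-dimethylphenyl for 2,4-dichlorophenyl gives a 7.4-fold higher number from compound 2 to compound 3 (0.87 log units; beyond the scatter) even though both groups have the same count of heavy atoms and neither has hydrogen-bond donors or acceptors. Going by these compounds alone, changing this one ring can also shift the number further, with a 43-fold higher number from compound 1 to compound 3 (1.63 log units; beyond the scatter) as the widest step so far. No measurement here explains why these rings differ.

Going by these compounds, it remains open how a plain unsubstituted phenyl or a phenyl carrying a single chlorine would compare. A phenyl bearing an amine or a carboxylic acid is equally untested in these compounds.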